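Phenyl for 2-Carboxyethyl on a Second Core

The source may hold more compounds than are shown below. What is called first, only, known or untested is meant among the compounds shown, and "the series" means these compounds.

Compound 1 `CC1=CC[C@H]2[C@H](CC[C@]2(C)O)C(C)(C)[C@@H]1CC[C@H]1[C@]2(C)CC[C@H](OC(=O)CCC(=O)O)C(C)(C)O[C@H]2CC[C@@]1(C)O` and compound 2 `CC1=CC[C@H]2[C@H](CC[C@]2(C)O)C(C)(C)[C@@H]1CC[C@H]1[C@]2(C)CC[C@H](OC(=O)c3ccccc3)C(C)(C)O[C@H]2CC[C@@]1(C)O` share one core and differ in a single place. In a functional assay on MCF7 cells (Homo sapiens) for antiproliferative activity, read by MTT assay, with a stated time of 72 h (a lower number here means a stronger inhibitor, a higher number a weaker inhibitor), compound 1 gives only a limit of the assay, > 50000 nM. Compound 2 gives 21000 nM in this assay. The change between them is phenyl in place of 2-carboxyethyl on a carbonyl carbon, and the step it made is an at least 2.3-fold lower number from compound 1 to compound 2 (0.37 log units; beyond the scatter); since two of the three values sit at the limit of > 50000 nM in this assay, at which 2 of the 3 values shown sit, the size of that step is known only as a lower bound.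

Compound 3 `CC1=CC[C@H]2[C@@H]1CC=C(C)[C@@H](CC[C@H]1[C@]3(C)CC[C@H](OC(=O)CCC(=O)O)C(C)(C)O[C@H]3CC[C@@]1(C)O)C2(C)C` carries the same 2-carboxyethyl group on a different core; how the two cores differ is not broken down here. In this assay compound 3 gives only a limit of the assay, > 50000 nM.

Compound 4 `CC1=CC[C@H]2[C@@H]1CC=C(C)[C@@H](CC[C@H]1[C@]3(C)CC[C@H](OC(=O)c4ccccc4)C(C)(C)O[C@H]3CC[C@@]1(C)O)C2(C)C` differs from compound 3 by phenyl in place of 2-carboxyethyl on a carbonyl carbon. The surroundings of the place are the same word for word as before, so this is the same change as from compound 1 to compound 2. The expected step is an at least 2.0-fold lower number from compound 3 to compound 4 (0.30 log units; that floor lies within the scatter), resting on the earlier step of an at least 2.3-fold lower number from compound 1 to compound 2 (0.37 log units; beyond the scatter). It also rests on the limit of compound 3, > 50000 nM. Compound 4 is therefore estimated at 25000 nM, with a real chance that only a limit is reported.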

Compound 4, half-maximal inhibitory concentration: 23100 nM
Beside the measured number, compound 4's estimate is 1.1-fold (0.03 log units) above it, and the stated range covers the measured number.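

On the second core, phenyl in place of 2-carboxyethyl on a carbonyl carbon gives an at least 2.1-fold lower number from compound 3 to compound 4 (0.33 log units; beyond the scatter) in this assay, so the change lowers the number on both cores shown, and it carries over in direction: the same change on two cores in this assay, an at least 2.3-fold lower number (0.37 log units; beyond the scatter) from compound 1 to compound 2 and an at least 2.1-fold lower number (0.33 log units; beyond the scatter) from compound 3 to compound 4; the limit leaves it open whether they differ. The size of each step is known only as a floor, which means the data cannot say whether the change is worth the same on both cores: the limit of > 50000 nM in this assay, at which 2 of the 4 values shown sit. Two cores are also a small sample, so nothing here shows that the change would behave the same way on a third core.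

The compounds shown leave open whether the step comes from adding the aromatic ring or from losing the carboxylic acid at the end of the chain. A saturated carbon chain without the acid, a methyl ester of the same chain, or a benzoyl group carrying an amine could help to separate those two readings.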